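Naphthyloxyacetohydrazones: tolerance on MT4 cells, halogen variation

A few compounds are considered here, and "the series" means these few. Any claim that something is new, unique, unknown or untested is made for them only; others in the source may bear on it.

Measured so far:
compound 1, `O=C(COc1cccc2ccccc12)N/N=C/c1ccccc1[N+](=O)[O-]`, 12.2 ug/mL
compound 2, `C/C(=N\NC(=O)COc1cccc2ccccc12)c1ccc(O)cc1`, 68.8 ug/mL
compound 3, `O=C(COc1cccc2ccccc12)N/N=C/c1ccccc1Cl`, 56.2 ug/mL

In an ADME assay on MT4 cells (Homo sapiens) for cytotoxicity, read by MTT assay, with a stated time of 4 days (a lower number here means that less compound is tolerated, a higher number that more compound is tolerated), compound 3 sits close to compound 2; the two numbers lie within the scatter of each other. Against compound 1 the step of a 4.6-fold higher number from compound 1 to compound 3 (0.66 log units; beyond the scatter) is the only one beyond the scatter in the set.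

Compound 4, `O=C(COc1cccc2ccccc12)N/N=C/c1ccc(Br)cc1`, differs from compound 3 in one place: 4-bromophenyl in place of 2-chlorophenyl on a carbon with a double bond to nitrogen. Going by the values given here, no measured step swaps one halogen for another or moves a halogen on that ring; the single step to hand, a 4.6-fold higher number from compound 1 to compound 3 (0.66 log units; beyond the scatter), concerns a nitro group and does not bear directly on this change. Nothing therefore argues for a step beyond the scatter in this assay for compound 4, and the number expected is close to that of compound 3, with a 1.1-fold lower number from compound 3 to compound 4 (0.05 log units; within the scatter) as the expected step. Compound 4 is estimated at 50 ug/mL, between 20 ug/mL and 120 ug/mL.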

Compound 4, half-maximal cytotoxic concentration: 106 ug/mL
For compound 4 the middle estimate is 2.1-fold (0.33 log units) below the measured one; measured number inside the range.
By their numbers in this assay, from the lowest: compound 1; then compounds 3, 2 and 4 (each within the scatter of the next).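

In this assay, the exchange of 2-chlorophenyl for 4-bromophenyl on a carbon with a double bond to nitrogen gives a 1.9-fold higher number from compound 3 to compound 4 (0.28 log units; within the scatter), so this position accepts a change of both halogen and ring place without a step beyond the scatter. The halogen and its place change together in this one step, so neither can be read alone. Nothing available accounts for the step.

Open remain the separate contributions of the halogen and of its place on this ring. Also open, on these data alone, is whether an amine or a carboxylic acid on the ring would stay within the scatter of compound 4.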